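The source may report more compounds than this note shows. Statements on the series, on what has been measured and on what is new or still open speak of the compounds shown alone.

Three compounds of the series have numbers in an assay on isolated protein for inhibition of phosphatidylinositol 4,5-bisphosphate 3-kinase catalytic subunit beta isoform (Homo sapiens); on this read-out lower numbers stand for stronger inhibition and higher numbers for weaker inhibition. Compound 1 `O=[N+]([O-])c1ccc(Nc2nccc(-c3ccc(Br)cc3)n2)cc1` gives 961 nM. Compound 2 `O=[N+]([O-])c1ccc(Nc2nccc(-c3ccc(F)cc3)n2)cc1` gives 863 nM, and the step of a 1.1-fold lower number from compound 1 to compound 2 (0.05 log units; within the scatter) shows that exchanging one halogen for another on the pendant phenyl ring changes little. Compound 3 `O=[N+]([O-])c1ccc(Nc2nccc(-c3ccc(Cl)c(Cl)c3)n2)cc1`, which carries the 3,4-dichlorophenyl group, gives 573 nM; this is the lowest of the three numbers, but the steps of a 1.7-fold lower number from compound 1 to compound 3 (0.22 log units; within the scatter) and a 1.5-fold lower number from compound 2 to compound 3 (0.18 log units; within the scatter) both stay inside the usual scatter, so compound 3 cannot be called more potent than compound 1 or compound 2 on the evidence in hand.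

Compound 4 `O=[N+]([O-])c1ccc(Nc2nccc(-c3ccc(Cl)cc3Cl)n2)cc1` has not been measured. Its change from compound 3 is 2,4-dichlorophenyl in place of 3,4-dichlorophenyl on an aromatic carbon: the same two chlorines on the same ring, joined differently. The measured steps that bear on this are those that altered the halogen pattern on that ring, a 1.7-fold lower number from compound 1 to compound 3 (0.22 log units; within the scatter) and a 1.5-fold lower number from compound 2 to compound 3 (0.18 log units; within the scatter), and neither left the scatter; the same holds for a 1.1-fold lower number from compound 1 to compound 2 (0.05 log units; within the scatter). Nothing in the measured set points to a move beyond the scatter in this assay for a change of this kind. A small step is therefore expected, a 1.1-fold higher number from compound 3 to compound 4 (0.05 log units; within the scatter). Compound 4 is estimated at 650 nM, with a range from 300 nM to 1400 nM.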

Compound 4, half-maximal inhibitory concentration: 938 nM
Beside the measured number, compound 4's estimate is 1.4-fold (0.16 log units) below it, within the range that was stated.
By their numbers in this assay, from the lowest: compounds 3, 2, 4 and 1 (each within the scatter of the next).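

Moving one chlorine while keeping the same atoms gives the first isomer pair on this ring in this assay, and a 1.6-fold higher number from compound 3 to compound 4 (0.21 log units; within the scatter) shows that placing a chlorine on the ring position of the 2,4-dichlorophenyl group, rather than the 3,4-dichlorophenyl arrangement, gives no readable difference. The 2,4-dichlorophenyl group is equally unseparated from the singly halogenated compounds, with a 1.1-fold higher number from compound 2 to compound 4 (0.04 log units; within the scatter) and a 1.0-fold lower number from compound 1 to compound 4 (0.01 log units; within the scatter), so all four halogen patterns at this position now lie within the scatter of one another. No supporting data accompany this result, so the closeness of these numbers stays without an explanation.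

The compounds shown leave open whether any change at this position can move the number beyond the scatter, since every pendant phenyl ring here carries only halogens; an amine, a carboxylic acid or a methoxy group on that ring would put this to the test. They also leave open what the nitro group on the other ring contributes, for which a nitrile or an amide in its place would provide the comparison.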